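Chloro for Fluoro in a Cytotoxicity Series

This account rests on a few compounds, and the source may have more. Where it says the series, first, only, none or still open, it means among the compounds named here.

For the measured compounds named here, compound 1 `C/C(=N\N=C1/SCC(=O)N1Cc1cccc(F)c1)c1cccs1` holds the highest of the two numbers known in an ADME assay on HEp-2 cells (Homo sapiens) for cytotoxicity, read by trypan blue exclusion, with a stated time of 24 h (a higher number here means that more compound is tolerated, a lower number that less compound is tolerated), where compound 1 gives 6 ug/mL. Its nearest neighbour, compound 2 `CC(C)=N/N=C1\SCC(=O)N1Cc1cccc([N+](=O)[O-])c1`, gives 5 ug/mL in this assay, a gap within the scatter, so the two cannot be told apart. Compound 3 `C/C(=N\N=C1/SCC(=O)N1Cc1cccc(Cl)c1)c1cccs1` is unmeasured and differs from compound 1 by chloro in place of fluoro on an aromatic carbon. Going by the values given here, no step between measured compounds covers this change, so the expectation rests on compound 1 alone. For compound 3 the expected step is a 1.2-fold lower number from compound 1 to compound 3 (0.08 log units; within the scatter), nothing beyond the scatter. Compound 3 is estimated at 5 ug/mL, within 2.5 ug/mL to 12 ug/mL.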

Compound 3, half-maximal cytotoxic concentration in the HEp-2 assay: 21 ug/mL
Beside the measured number, compound 3's estimate is 4.2-fold (0.62 log units) below it; the measured number lies above the stated range.
By their numbers in the HEp-2 assay, from the lowest: compounds 2 and 1 (each within the scatter of the next); then compound 3.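

For the compounds shown here, at this position on the ring, chloro in place of fluoro gives a 3.5-fold higher number from compound 1 to compound 3 (0.54 log units; beyond the scatter) in the HEp-2 assay and is the only step here beyond the scatter. The same change barely registers in a physicochemical assay, with a stated time of 90 min (a higher number here means that more compound is needed for the effect, a lower number that less compound is needed), where compound 1 gives 1360000 nM and compound 3 gives 1160000 nM, a pair within the scatter. No measurement shown accounts for the difference between the two assays.

From the compounds shown here alone, whether bromo, methoxy or an amine at this position would follow chloro remains open. So does whether the step would recur on a different core.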